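Cyclohexyl for Benzyl on an Amide Nitrogen, Seen Twice

The source may hold more compounds than are shown below. What is called first, only, known or untested is meant among the compounds shown, and "the series" means these compounds.

Measured in a functional assay on MDA-MB-231 cells (Homo sapiens) for cytotoxicity, read by MTT assay, with a stated time of 72 h; on this read-out lower numbers stand for stronger inhibition and higher numbers for weaker inhibition:
Compound 1 `COc1ccc(/C(=C(/CCNC(=O)NCc2ccccc2)c2ccccc2)c2ccccc2)cc1` gives > 50000 nM, a limit of the assay.
Compound 2 `COc1ccc(/C(=C(/CCNC(=O)NC2CCCCC2)c2ccccc2)c2ccccc2)cc1` gives > 50000 nM, also a limit of the assay.
Compound 3 `COc1ccc(/C(=C(/CCNC(=O)C(=O)NCc2ccccc2)c2ccccc2)c2ccccc2)cc1` gives 11500 nM.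

Compound 1 and compound 2 differ by cyclohexyl in place of benzyl on an amide-type nitrogen. The step that the two limits leave unreadable from compound 1 to compound 2 cannot be read because of the limit of > 50000 nM in this assay, at which 2 of the 3 values shown sit. Compound 3 differs from compound 1 by benzylcarbamoyl in place of benzylamino on a carbonyl carbon, and this change gives an at least 4.3-fold lower number from compound 1 to compound 3 (0.63 log units; beyond the scatter); measured against compound 2 the same direction is seen in an at least 4.3-fold lower number from compound 2 to compound 3 (0.63 log units; beyond the scatter). Going by the values given here, compound 3 thus carries the only number in this set.

Compound 4 `COc1ccc(/C(=C(/CCNC(=O)C(=O)NC2CCCCC2)c2ccccc2)c2ccccc2)cc1` is not yet measured. It differs from compound 3 by cyclohexyl in place of benzyl on an amide-type nitrogen, the same change as that from compound 1 to compound 2, made at a place described in identical words; what differs between the two cores is the change told above from compound 1 to compound 3.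

The earlier occurrence of this change gives no readable size, so the expectation for compound 4 rests mainly on the value of compound 3 in this assay. Compound 4 is expected to sit close to compound 3, with the step of a 1.2-fold higher number from compound 3 to compound 4 (0.09 log units; within the scatter) estimated as small. For compound 4 the estimate is 14000 nM, expected to lie between 4000 nM and 50000 nM.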

Compound 4, half-maximal inhibitory concentration: 12200 nM
Compound 4: the middle estimate sits 1.1-fold (0.06 log units) above what was measured; low and high end bracket the measured number.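

In this assay, cyclohexyl in place of benzyl on an amide-type nitrogen on the core of compound 3 gives a 1.1-fold higher number from compound 3 to compound 4 (0.03 log units; within the scatter), so on this core the two groups cannot be told apart. This single readable step does not show that the change carries the same size from one core to the other, since the same change on the core of compound 1 leaves no size to set beside it: the limit of > 50000 nM in this assay, at which 2 of the 4 values shown sit. Reached from the other core, compound 4 shows an at least 4.0-fold lower number from compound 1 to compound 4 (0.61 log units; beyond the scatter) and an at least 4.0-fold lower number from compound 2 to compound 4 (0.61 log units; beyond the scatter), so the lower numbers stay with the core of compound 3 whether benzyl or cyclohexyl is present, although both sizes are bounds and not measured distances.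

The compounds shown carry only benzyl and cyclohexyl on this nitrogen, which leaves open how a smaller group such as methyl or a longer chain such as phenethyl would read on the core of compound 3. They also leave open what an amine or a carboxylic acid on the ring of the benzyl group would do to the number in this assay.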